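Lengthening a Saturated Chain and Cytotoxicity on A549 Cells

A few compounds are considered here, and "the series" means these few. Any claim that something is new, unique, unknown or untested is made for them only; others in the source may bear on it.

The study compares three measured compounds and one still to be measured, all sharing one core and differing only in the length of a saturated chain attached through an oxygen next to a carbonyl group. Compound 1 `CCCCCCCCCOC(=O)CCC(=O)N1CCN(CCCOc2cc3c(Nc4ccc(F)c(Cl)c4)ncnc3cc2OC)CC1` in a functional assay on A549 cells (Homo sapiens) for cytotoxicity, read by MTT assay, with a stated time of 24 h, tested at 40 uM (a lower number here means a stronger effect, a higher number a weaker effect of the compound at the concentration tested), gives 17.9%. Compound 2 `CCCCCCCCCCOC(=O)CCC(=O)N1CCN(CCCOc2cc3c(Nc4ccc(F)c(Cl)c4)ncnc3cc2OC)CC1` differs from it by methyl in place of hydrogen on a saturated chain carbon, nine bonds along the chain from an oxygen next to a carbonyl group, and in this assay compound 2 gives 15.5%, so that a number 2.4 percentage points lower from compound 1 to compound 2 (within the scatter). Compound 3 `CCCCCCCCCCCCCOC(=O)CCC(=O)N1CCN(CCCOc2cc3c(Nc4ccc(F)c(Cl)c4)ncnc3cc2OC)CC1` is set apart from compound 1 by butyl in place of hydrogen on a saturated chain carbon, nine bonds along the chain from an oxygen next to a carbonyl group; in this assay compound 3 gives 71.1%, and a number 53.2 percentage points higher from compound 1 to compound 3 (beyond the scatter). Against compound 2 the change is larger still, since a number 55.6 percentage points higher from compound 2 to compound 3 (beyond the scatter).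

Compound 4 `CCCCCCCCCCCCCCOC(=O)CCC(=O)N1CCN(CCCOc2cc3c(Nc4ccc(F)c(Cl)c4)ncnc3cc2OC)CC1` is the next member: it differs from compound 3 by methyl in place of hydrogen on a saturated chain carbon, ten or more bonds along the chain from an oxygen next to a carbonyl group. Within the data shown here, this is the same kind of change as the one from compound 1 to compound 2, though the place along the chain is not identical, as the two difference descriptions show. That earlier step stayed within the scatter, and on that basis the expected step from compound 3 to compound 4 is small, a number 1.9 percentage points higher from compound 3 to compound 4 (within the scatter), resting on the measured a number 2.4 percentage points lower from compound 1 to compound 2 (within the scatter). Compound 4 is therefore estimated to give about 73% in this assay, with a likely range from 55% to 90%.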

Compound 4, a percentage reported as activity, at one concentration (the size of the read-out at that concentration, not a potency): 88.6%
Estimate against measurement, compound 4: 15.6 percentage points below, within the range that was stated.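

In this assay the methyl change does not carry over with the same size from one chain to the next, since the new step is a number 17.5 percentage points higher from compound 3 to compound 4 (beyond the scatter), and it stands apart from the earlier one: the same change on two cores in this assay, a number 2.4 percentage points lower (within the scatter) from compound 1 to compound 2 and a number 17.5 percentage points higher (beyond the scatter) from compound 3 to compound 4, 19.9 percentage points apart, beyond the scatter of two such steps

The butyl change also differs with its starting chain, with a number 73.1 percentage points higher from compound 2 to compound 4 (beyond the scatter), while the pentyl change gives a number 70.7 percentage points higher from compound 1 to compound 4 (beyond the scatter), and the two butyl steps compare as follows: the same change on two cores in this assay, a number 53.2 percentage points higher (beyond the scatter) from compound 1 to compound 3 and a number 73.1 percentage points higher (beyond the scatter) from compound 2 to compound 4, 19.9 percentage points apart, beyond the scatter of two such steps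

This shows that, among these four compounds, a step measured on one chain length is a poor guide to the same step on another, but it does not show what lies behind the difference or whether it would hold for any change other than lengthening this chain.

From the compounds shown here alone, an undecyl or dodecyl chain would fall in the gap between compound 2 and compound 3, so where along the chain the read-out begins to rise remains open. Going by these compounds, whether a longer chain continues the rise and what a chain ending in an amine or a carboxylic acid would give in this assay also remain open.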